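Dichlorophenyl urea tested against a kidney cancer line

This account rests on a few compounds, and the source may have more. Where it says the series, first, only, none or still open, it means among the compounds named here.

compound 1, `O=C(Nc1cccc(-n2cc(-c3ccncc3)c(-c3ccc(Cl)c(O)c3)n2)c1)Nc1cccc(C(F)(F)F)c1`: > 32500 nM
compound 2, `COc1cc(-c2nn(-c3cccc(NC(=O)Nc4cc(C(F)(F)F)cc(C(F)(F)F)c4)c3)cc2-c2ccncc2)ccc1Cl`: 7140 nM

In a functional assay on A498 cells (Homo sapiens) for inhibition, read by sulforhodamine B assay, with a stated time of 48 h (a higher number here means that more compound is tolerated, a lower number that less compound is tolerated), compound 1 reaches only a limit, > 32500 nM, the point where one of the two values sits (the limit of > 32500 nM in this assay, at which 1 of the 2 values shown sits). In this assay, within the data shown here, compound 2 gives 7140 nM, but it differs from compound 1 in more than one place, so the two values show only that compound 2 is within range and compound 1 is not.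

Compound 3, `O=C(Nc1cccc(-n2cc(-c3ccncc3)c(-c3ccc(Cl)c(O)c3)n2)c1)Nc1ccc(Cl)c(Cl)c1`, carries the change (3,4-dichlorophenyl in place of 3-(trifluoromethyl)phenyl on an amide-type nitrogen), that is, 3,4-dichlorophenyl in place of 3-(trifluoromethyl)phenyl on an amide-type nitrogen. With only a limit as the starting point, the expected step is an at least 1.0-fold lower number from compound 1 to compound 3 (0.03 log units; that floor lies within the scatter), not beyond the scatter. Compound 3 is estimated at 30000 nM, between 9000 nM and 90000 nM.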

Compound 3, concentration lethal to 50% of the cells: > 32500 nM
Compound 3: only a limit was reported; the forecaster's own chance of this, stated with the estimate: 50%; at least 1.0-fold (0.03 log units) between middle value and limit.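

In this assay compound 3 gives > 32500 nM, which is a limit. Compound 1 also stands at a limit, so no step between compound 1 and compound 3 can be read: the limit of > 32500 nM in this assay, at which 2 of the 3 values shown sit.

The compounds shown leave open whether 3,4-dichlorophenyl in place of 3-(trifluoromethyl)phenyl changes the value at all.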